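From azido to fluoro on the shared core

This account rests on a few compounds, and the source may have more. Where it says the series, first, only, none or still open, it means among the compounds named here.

In a functional assay on CCRF-CEM cells (Homo sapiens) for inhibition (on this read-out lower numbers stand for stronger inhibition and higher numbers for weaker inhibition), compound 1 (`O=c1[nH]c(=O)n(C2O[C@H](CBr)[C@@H](O)[C@H]2O)cc1F`) gives 3100 nM, while compound 2 (`[N-]=[N+]=NC[C@H]1OC(n2cc(F)c(=O)[nH]c2=O)[C@H](O)[C@@H]1O`) gives 350000 nM, the higher of the two numbers. Compound 3 (`O=c1[nH]c(=O)n(C2O[C@H](CF)[C@@H](O)[C@H]2O)cc1F`) awaits measurement and differs from compound 2 thus: fluoro in place of azido on a saturated chain carbon bound to a saturated ring carbon. Among the measured compounds shown here, the only measured step bearing on this is the large 110-fold higher number from compound 1 to compound 2 (2.05 log units; beyond the scatter), with azido in place of bromo. For the measured compounds named here, no fluoro analogue has been measured yet, so only part of that large step is expected to be regained. The expected change is a 35-fold lower number from compound 2 to compound 3 (1.54 log units; beyond the scatter), a sizeable move to a lower number. Compound 3 is estimated at 10000 nM, with an expected range of 2000 nM to 60000 nM.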

Compound 3, half-maximal inhibitory concentration: 140000 nM
For compound 3 the middle estimate is 14-fold (1.15 log units) below the measured one, outside the stated range (above it).
By their numbers in this assay, from the lowest: compound 1; then compound 3; then compound 2.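

In this assay, fluoro on this saturated chain carbon regains little of what azido lost: replacing azido gives a 2.5-fold lower number from compound 2 to compound 3 (0.40 log units; beyond the scatter) and replacing bromo gives a 45-fold higher number from compound 1 to compound 3 (1.65 log units; beyond the scatter). Among these three groups, compound 3 therefore lies much closer to compound 2 than to compound 1, and bromo alone gives a low number. No evidence at hand accounts for this order. Going by these compounds, it remains open whether chloro or iodo at this place would match bromo, and whether an amine or a hydroxyl would fall with fluoro and azido.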